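Allyl to isobutyl carbamate on a selenocyanate core

This account rests on a few compounds, and the source may have more. Where it says the series, first, only, none or still open, it means among the compounds named here.

Measured compounds:
Compound 1 `C=CCOC(=O)Nc1ccc([Se]C#N)cc1` gives 27000 nM in a functional assay on HTB-54 cells (Homo sapiens) for cytotoxicity, read by MTT assay, with a stated time of 72 h; on this read-out higher numbers stand for weaker inhibition of growth and lower numbers for stronger inhibition of growth.
Compound 2 `O=C(Nc1ccc([Se][Se]c2ccc(NC(=O)Oc3ccccc3)cc2)cc1)Oc1ccccc1` gives 22700 nM in this assay.

Compound 1 holds the highest of the two numbers, but compound 2 lies within the scatter of it, so the two values show no order. Compound 3 `CC(C)COC(=O)Nc1ccc([Se]C#N)cc1` differs from compound 1 by isopropyl in place of vinyl on a saturated chain carbon bound to an oxygen next to a carbonyl group, a small change on the carbamate chain, far from the selenium group. Within the data shown here, no measured step between the two compounds exists, so the expectation rests on compound 1 alone. The step of a 1.1-fold lower number from compound 1 to compound 3 (0.03 log units; within the scatter) is expected to stay within the scatter, in no clear direction. Compound 3 is therefore estimated at 25000 nM, with a range from 10000 nM to 60000 nM.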

Compound 3, concentration for 50% growth inhibition: 27100 nM
For compound 3 the middle estimate is 1.1-fold (0.04 log units) below the measured one, and the stated range covers the measured number.
By their numbers in this assay, from the lowest: compounds 2, 1 and 3 (each within the scatter of the next).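

Among these compounds, the change from allyl to isobutyl in this assay gives a 1.0-fold higher number from compound 1 to compound 3 (0.00 log units; within the scatter) and so offers the first direct comparison at this place on the carbamate chain. For this pair, losing the double bond outside the aromatic ring and gaining a carbon leaves the two values indistinguishable. No supporting measurement bears on why this is so. The compounds shown leave open whether a longer chain, an amine or a carboxylic acid at this place would move the number beyond the scatter. They also leave open whether the same change behaves alike on another core.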